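Ester variation and rat microsomal half-life: compound 4

A few compounds are considered here, and "the series" means these few. Any claim that something is new, unique, unknown or untested is made for them only; others in the source may bear on it.

Measured in an ADME assay (liver) for pharmacokinetics, with Liver microsome (Rattus norvegicus) as the target, using microsomes; on this read-out lower numbers stand for a shorter-lived compound and higher numbers for a longer-lived compound:
compound 1 `CCOc1cc(NC(=O)C2(NC(=O)c3ccc4c(C5CCCC5)c(-c5ncc(Cl)cn5)n(C)c4c3)CCC2)ccc1/C=C/C(=O)OCOP(=O)(O)OC(C)(C)C`: 0.133 h
compound 2 `CCOc1cc(NC(=O)C2(NC(=O)c3ccc4c(C5CCCC5)c(-c5ncc(Cl)cn5)n(C)c4c3)CCC2)ccc1/C=C/C(=O)OCC(Cl)(Cl)Cl`: 0.233 h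
compound 3 `CCCN(C)C(=O)COC(=O)/C=C/c1ccc(NC(=O)C2(NC(=O)c3ccc4c(C5CCCC5)c(-c5ncc(Cl)cn5)n(C)c4c3)CCC2)cc1OCC`: 0.317 h

Compound 3 holds the highest of the three numbers, though only one gap is clear: a 2.4-fold higher number from compound 1 to compound 3 (0.38 log units; beyond the scatter), whereas a 1.4-fold higher number from compound 2 to compound 3 (0.13 log units; within the scatter). Compound 4 `CCOc1cc(NC(=O)C2(NC(=O)c3ccc4c(C5CCCC5)c(-c5ncc(Cl)cn5)n(C)c4c3)CCC2)ccc1/C=C/C(=O)OCC(=O)N1CCOCC1` differs from compound 3 in morpholin-4-yl in place of methyl(propyl)amino on a carbonyl carbon. No measured step alters only the amine part of this group; every step so far replaces the whole group on the saturated chain carbon bound to an oxygen next to a carbonyl group, and these were small: a 1.8-fold higher number from compound 1 to compound 2 (0.24 log units; within the scatter), with the other two given above. On that basis, a step no larger than the scatter is expected in this assay, so a 1.1-fold lower number from compound 3 to compound 4 (0.02 log units; within the scatter) is the estimate. Compound 4 is expected to give 0.3 h, within 0.15 h to 0.6 h.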

Compound 4, half-life: 0.733 h
The estimate for compound 4 lay 2.4-fold (0.39 log units) below the measured number, and the stated range ends below it.
By their numbers in this assay, from the lowest: compounds 1, 2 and 3 (each within the scatter of the next, the first and the last beyond it); then compound 4.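

In this assay, the amine part on the carbonyl carbon is not neutral: morpholin-4-yl in place of methyl(propyl)amino gives a 2.3-fold higher number from compound 3 to compound 4 (0.36 log units; beyond the scatter), the only step shown that alters the amine part alone. Compound 4 also stands clear of the other esters, with a 3.1-fold higher number from compound 2 to compound 4 (0.50 log units; beyond the scatter) and a 5.5-fold higher number from compound 1 to compound 4 (0.74 log units; beyond the scatter). No supporting data bear on the origin of these differences.

Going by these compounds, whether the step follows the ring or its oxygen stays open; piperidin-1-yl on the same carbonyl carbon, which keeps the six-membered ring without the oxygen, would separate the two.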